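The compounds below may be only part of what the source reports. "The series", "measured", "known", "first", "only" and "open" are said of these compounds alone.

Compound 2 `COc1cc(Oc2cccc(Nc3ccccc3)c2)cc(OC)c1CCO` stands only at a limit in a functional assay on SW-620 cells (Homo sapiens) for inhibition, read by MTT assay, with a stated time of 72 h (a lower number here means a stronger inhibitor, a higher number a weaker inhibitor), the limit being > 20000 nM. Compound 1 `CNCc1c(OC)cc(Oc2cccc(Nc3ccccc3)c2)cc1OC` gives 15000 nM in this assay. Among the measured compounds shown here, the single measured step, an at least 1.3-fold higher number from compound 1 to compound 2 (0.12 log units; that floor lies within the scatter), rests on the limit (the limit of > 20000 nM in this assay, at which 1 of the 2 values shown sits), so its true size is open. Compound 3 `COc1cc(Oc2cccc(Nc3ccccc3)c2)cc(OC)c1CNCc1ccc(Br)cc1` differs from compound 2 by (4-bromobenzyl)amino in place of hydroxymethyl on a saturated chain carbon bound to an aromatic carbon. For the measured compounds named here, no measured step covers this change; an amine on that carbon returns, and compound 1 with its amine showed 15000 nM. Compound 3 is therefore expected at 5000 nM, within 1500 nM to 20000 nM. That estimate means a step of an at least 4.0-fold lower number from compound 2 to compound 3 (0.60 log units; beyond the scatter) in this assay.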

Compound 3, half-maximal inhibitory concentration: 11200 nM
For compound 3 the middle estimate is 2.2-fold (0.35 log units) below the measured one; the range from low to high includes it.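

In this assay the amine series takes 4-bromophenyl on a saturated chain carbon bound to an amine nitrogen with a 1.3-fold lower number from compound 1 to compound 3 (0.13 log units; within the scatter) and so the two amines do not separate. The value of compound 2 is a limit, so an at least 1.7-fold lower number from compound 2 to compound 3 (0.25 log units; that floor lies within the scatter) gives only a floor for the exchange of hydroxymethyl for (4-bromobenzyl)amino: the limit of > 20000 nM in this assay, at which 1 of the 3 values shown sits.

Open, from the compounds shown here alone, is whether the bromine plays any part, which a plain benzylamino group would test. Also open, going by these compounds, is whether a carboxylic acid or a longer chain on that carbon would move the number beyond the scatter.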